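Trimming a tert-butyl amide: compound 2 to compound 3

The source may hold more compounds than are shown below. What is called first, only, known or untested is meant among the compounds shown, and "the series" means these compounds.

Of the compounds shown here, two sharing a common core have been measured in an in vitro assay on BaF3 cells for displacement of a labelled ligand from C-X-C chemokine receptor type 3 (Homo sapiens); a higher number here means a weaker inhibitor, a lower number a stronger inhibitor. Compound 1, `CC[C@H]1CN(c2nc(N)c(C(=O)NCCO)nc2Cl)CCN1C1CCN(C(=O)c2ccc(Cl)nc2N)CC1`, carries a hydroxyethyl amide and an amino group on its central ring, and in this assay compound 1 gives 3.4 nM. Compound 2, `CC[C@H]1CN(c2ncc(C(=O)NC(C)(C)C)nc2Cl)CCN1C1CCN(C(=O)c2ccc(Cl)nc2N)CC1`, instead carries a tert-butyl amide and lacks the amino group, and in this assay compound 2 gives 1.5 nM. Of the two numbers, compound 2 has the lower one, and the gap to compound 1 lies beyond the usual scatter, so compound 2 is the stronger binder of the pair.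

The next compound, compound 3, `CC[C@H]1CN(c2ncc(C(=O)NC(C)C)nc2Cl)CCN1C1CCN(C(=O)c2ccc(Cl)nc2N)CC1`, differs from compound 2 in one place: hydrogen in place of methyl on a saturated chain carbon bound to an amide-type nitrogen and two saturated chain carbons, which leaves the tert-butyl amide as an isopropyl amide. Going by the values given here, no comparable step has been measured here, so the expectation rests on the smallness of the change alone. A step of about a 1.5-fold higher number from compound 2 to compound 3 (0.17 log units; within the scatter) is expected, that is, no change beyond the scatter, with a slight lean toward a weaker binder. Compound 3 is therefore estimated at 2.2 nM, within a range of 0.9 nM to 5.5 nM.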

Compound 3, half-maximal inhibitory concentration: 0.9 nM
Compound 3: middle estimate off by 2.4-fold (0.39 log units), on the high side; the measured number falls inside the stated range.
By their numbers in this assay, from the lowest: compounds 3 and 2 (each within the scatter of the next); then compound 1.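

In this assay the change from tert-butyl to isopropyl, with a single methyl leaving the amide chain, gives a 1.7-fold lower number from compound 2 to compound 3 (0.22 log units; within the scatter) and so leaves the two compounds indistinguishable in binding. This is the first pair shown that differs in one place only, which makes it the first direct reading of this position: the third methyl of the tert-butyl group is not needed to hold the number at this level, so this part of the amide tolerates a small trim. The data shown offer no explanation for how little this change does.

Going by these compounds, how far the trimming can go remains open: an ethyl amide, a methyl amide or the plain unsubstituted amide could tell whether binding holds once the branching on this carbon is gone, and a cyclopropyl amide or a longer chain such as a butyl amide could show how much other shapes are tolerated here. The separate contributions of the hydroxyethyl amide and the amino group of compound 1 also stay unresolved, since compound 1 differs from the other two compounds in more than one place.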